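This account rests on a few compounds, and the source may have more. Where it says the series, first, only, none or still open, it means among the compounds named here.

Measured so far:
Compound 1, `Cc1ccc(Nc2nc(C(F)(F)F)ccc2CNC(=O)C(C)c2ccc(NS(C)(=O)=O)c(F)c2)cc1C`, gives 39.3 nM in a functional assay on CHO-K1 cells for antagonist activity at transient receptor potential cation channel subfamily V member 1 (Homo sapiens), read by FLIPR; on this read-out higher numbers stand for weaker inhibition and lower numbers for stronger inhibition.
Compound 2, `CC(C)OC1CCN(c2nc(C(F)(F)F)ccc2CNC(=O)C(C)c2ccc(NS(C)(=O)=O)c(F)c2)CC1`, gives 3 nM in this assay.

Among the measured compounds shown here, of the two numbers, compound 2 holds the lower one, and the only neighbour is compound 1: the step of a 13-fold lower number from compound 1 to compound 2 (1.12 log units; beyond the scatter) swaps the arylamino group of compound 1 for the isopropoxypiperidinyl group of compound 2 and is well beyond the scatter.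

Compound 3, `CC(=O)OC1CCN(c2nc(C(F)(F)F)ccc2CNC(=O)C(C)c2ccc(NS(C)(=O)=O)c(F)c2)CC1`, keeps the whole framework of compound 2 and alters only the far end of that piperidine: acetyl in place of isopropyl on an oxygen on a saturated carbon. For the measured compounds named here, the single measured step says nothing directly about this spot, since it exchanged the entire substituent on the aromatic carbon rather than the group on the oxygen. Going by the values given here, there is therefore no measured precedent either for a gain or for a loss at this position. With so small a change in size, the working expectation for compound 3 is a step of a 1.7-fold higher number from compound 2 to compound 3 (0.22 log units; within the scatter), that is, no movement clearly beyond the scatter, with a slight lean towards a higher number. On that basis compound 3 is estimated at 5 nM in this assay, within a range of 1.5 nM to 18 nM.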

Compound 3, inhibition constant: 4 nM
Compound 3: middle estimate off by 1.3-fold (0.10 log units), on the high side; the measured number falls inside the stated range.
By their numbers in this assay, from the lowest: compounds 2 and 3 (each within the scatter of the next); then compound 1.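

In this assay the exchange of isopropyl for acetyl on the oxygen gives a 1.3-fold higher number from compound 2 to compound 3 (0.12 log units; within the scatter) and so leaves compound 2 and compound 3 indistinguishable, even though the entering group brings a hydrogen-bond acceptor and a double bond that the leaving group lacks. The earlier step replaced the whole substituent on the aromatic carbon, whereas this one shows that the far end of the piperidine can be altered in this way without a difference that stands clear of the scatter, and the advantage over the arylamino group of compound 1 remains, with a 9.8-fold lower number from compound 1 to compound 3 (0.99 log units; beyond the scatter) as the step from that compound. Nothing measured here accounts for the close agreement between the isopropoxy and acetoxy compounds.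

Going by these compounds, two groups on one oxygen are a narrow sample, so it remains open whether a free hydroxyl, a longer chain such as butyl, a carboxylic acid or an amine at this end of the piperidine would stay this close. On these data alone, it also remains open whether an amide nitrogen could take the place of that oxygen while the number stays in the same range.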